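Methoxymethyl to Hydroxymethyl on the Carbonyl Carbon

The compounds below may be only part of what the source reports. "The series", "measured", "known", "first", "only" and "open" are said of these compounds alone.

For the measured compounds named here, in an assay on RBL cells for inhibition of Polyunsaturated fatty acid 5-lipoxygenase (Rattus norvegicus) (on this read-out lower numbers stand for stronger inhibition and higher numbers for weaker inhibition), compound 3 `COCC(=O)N(O)C(C)c1ccc2oc(-c3ccccc3)cc2c1` gives 160 nM, the highest of the three numbers so far. Compound 1 `CC(c1ccc2oc(-c3ccccc3)cc2c1)N(O)C(=O)c1ccco1` gives 40 nM and compound 2 `COC(=O)CCCC(=O)N(O)C(C)c1ccc2oc(-c3ccccc3)cc2c1` gives 60 nM. The steps of a 4.0-fold higher number from compound 1 to compound 3 (0.60 log units; beyond the scatter) and a 2.7-fold higher number from compound 2 to compound 3 (0.43 log units; beyond the scatter) are both modest, whereas a 1.5-fold higher number from compound 1 to compound 2 (0.18 log units; within the scatter) stays within the scatter. Compound 4 `CC(c1ccc2oc(-c3ccccc3)cc2c1)N(O)C(=O)CO` differs from compound 3 by hydrogen in place of methyl on an oxygen on a saturated carbon. Going by the values given here, no measured step alters this oxygen itself; the two modest steps above exchanged the whole group on the carbonyl carbon, a larger change than removing one methyl. The estimated step is therefore a 1.3-fold higher number from compound 3 to compound 4 (0.10 log units; within the scatter), not beyond the scatter. Compound 4 is expected near 200 nM, within 80 nM to 500 nM.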

Compound 4, half-maximal inhibitory concentration: 700 nM
Compound 4: the middle estimate sits 3.5-fold (0.54 log units) below what was measured; measured number outside the range, above it.
By their numbers in this assay, from the lowest: compounds 1 and 2 (each within the scatter of the next); then compound 3; then compound 4.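

Loss of a single methyl is enough to shift the number in this assay (a 4.4-fold higher number from compound 3 to compound 4 (0.64 log units; beyond the scatter)), so the group on this oxygen is not a silent detail of the chain. Hydroxymethyl on the carbonyl carbon also gives the only large steps in the series (a 12-fold higher number from compound 2 to compound 4 (1.07 log units; beyond the scatter); an 18-fold higher number from compound 1 to compound 4 (1.24 log units; beyond the scatter)), while the earlier steps were modest or within the scatter. Nothing available explains this change.

Going by these compounds, whether an amine or a carboxylic acid in place of the hydroxy would track with hydroxymethyl or methoxymethyl stays open. So does the effect of a longer chain carrying the hydroxy.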